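The source may report more compounds than this note shows. Statements on the series, on what has been measured and on what is new or still open speak of the compounds shown alone.

Growth inhibition values in a functional assay on MV4-11 cells (Homo sapiens) for inhibition, read by luminescence and CellTiter-Glo, with a stated time of 72 h (a higher number here means a weaker inhibitor of growth, a lower number a stronger inhibitor of growth), for the measured members of the series:

compound 1 `CCC(=O)N1c2ccc(-c3ccc(S(C)(=O)=O)cc3)cc2N(C(=O)c2ccco2)C[C@@H]1C` gives 550 nM
compound 2 `CC(=O)N1c2ccc(-c3ccc(S(C)(=O)=O)cc3)cc2N(C(=O)c2ccco2)C[C@@H]1C` gives 400 nM
compound 3 `CC(=O)N1c2ccc(-c3ccc(S(C)(=O)=O)cc3)cc2N(C(=O)OC(C)C)C[C@@H]1C` gives 350 nM

Compound 1 has the highest of the three numbers, but all three sit within the scatter of one another: the step of a 1.4-fold lower number from compound 1 to compound 2 (0.14 log units; within the scatter) is small, and the values of compound 1 and compound 3 likewise lie within the scatter of each other. Going by the values given here, no compound can be called the strongest or weakest on these data.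

Compound 4 `COC(=O)N1c2ccc(-c3ccc(S(C)(=O)=O)cc3)cc2N(C(=O)c2ccco2)C[C@@H]1C` differs from compound 1 by methoxy in place of ethyl on a carbonyl carbon. Among the compounds with values here, two measured steps bear on this. The step of a 1.4-fold lower number from compound 1 to compound 2 (0.14 log units; within the scatter) shortens the chain on the same carbonyl carbon and stays within the scatter. The step of a 1.1-fold lower number from compound 2 to compound 3 (0.06 log units; within the scatter) exchanges an acyl group for a carbamate-type group on the other ring nitrogen of the shared core and also stays within the scatter. Neither change at either carbonyl has moved this assay beyond its noise, so no step beyond the scatter is expected for compound 4 either.

Compound 4 is therefore estimated at 480 nM in this assay, with a range of 220 nM to 1050 nM. This estimate means an expected step of a 1.1-fold lower number from compound 1 to compound 4 (0.06 log units; within the scatter).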

Compound 4, concentration for 50% growth inhibition: 320 nM
Estimate against measurement, compound 4: 1.5-fold (0.18 log units) above; measured number inside the range.
By their numbers in this assay, from the lowest: compounds 4, 3, 2 and 1 (each within the scatter of the next).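

In this assay the carbonyl carbon on the amide-type nitrogen in a ring now carries ethyl, methyl or methoxy, and the exchange of ethyl for methoxy gives a 1.7-fold lower number from compound 1 to compound 4 (0.24 log units; within the scatter) while the exchange of methyl for methoxy gives a 1.3-fold lower number from compound 2 to compound 4 (0.10 log units; within the scatter) on the same shared core. The earlier compounds shown here varied this place only by chain length, whereas these steps show that propanoyl to methoxycarbonyl, a change that brings in oxygen, also stays within the scatter. No supporting evidence bears on this result.

On these data alone, whether a longer chain such as butyl or an amine such as dimethylamino on this carbonyl carbon would give a step beyond the scatter remains open. Also open, as far as these compounds go, is whether the methoxy step would read the same with isopropoxy in place of furan-2-yl.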